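Shrinking the Ring Amine on a Low-Reading Compound

A few compounds are considered here, and "the series" means these few. Any claim that something is new, unique, unknown or untested is made for them only; others in the source may bear on it.

A pair of compounds built on a shared core have been tested in a functional assay on the whole organism with Rattus norvegicus as the target, at a dose of 20 mg/kg by the oral route; on this read-out higher numbers stand for more inhibition at the one dose given (going by the name of the read-out) and lower numbers for less inhibition. Compound 1 `NC(=O)/C=C1\CCc2cc(Cl)ccc21` gives 30% in this assay. Compound 2 `O=C(/C=C1\CCc2ccc(F)cc21)N1CCCC1` gives 10% in this assay. Compound 2 therefore stands lowest of the pair of numbers, and its nearest neighbour, compound 1, sits higher by a gap that lies beyond the usual scatter of repeated measurements. Going by the values given here, compound 1 and compound 2 differ in more than one place, so no single structural step connects them; only what their two values show can be said.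

Compound 3 `O=C(/C=C1\CCc2ccc(F)cc21)N1CCC1` has not yet been measured. It differs from compound 2 in one place: azetidin-1-yl in place of pyrrolidin-1-yl on a carbonyl carbon. The group that enters is again a ring amine with no donors, no acceptors and no charge, only smaller.

Among the compounds with values here, no measured pair shows what a change of this kind does in this assay. The step from compound 2 to compound 3 a number 5 percentage points higher from compound 2 to compound 3 (within the scatter) is expected to be small, most likely within the scatter, with a little room toward the higher side. Compound 3 is expected to give 15% in this assay, within a range from 0% to 35%.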

Compound 3, a percentage reported as inhibition, in the whole organism at one dose (the size of the read-out at that dose, not a potency): 14%
Compound 3: middle estimate off by 1 percentage points, on the high side; the range from low to high includes it.
By their numbers in this assay, from the lowest: compounds 2 and 3 (each within the scatter of the next); then compound 1.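

In this assay, going by these compounds alone, azetidin-1-yl in place of pyrrolidin-1-yl on a carbonyl carbon gives a number 4 percentage points higher from compound 2 to compound 3 (within the scatter), and this is the only single-place step in the set. It shows that, at this position, the five-membered ring amine and the four-membered ring amine cannot be told apart at the one dose given, so this reduction in ring size has no effect that stands clear of the scatter. The measurements shown offer no information on why the two ring amines read alike.

On these data alone, it remains open whether a larger ring amine such as piperidin-1-yl, or a ring with a second hetero atom such as morpholin-4-yl, on the same carbonyl carbon would stay level with compound 2 and compound 3 or separate from them. Compound 1 differs from both in more than one place, so its reading of 30% cannot be tied to the group on the carbonyl carbon or to any other single difference.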